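Dropping One Methoxy: From Compound 1 to Compound 3

This account rests on a few compounds, and the source may have more. Where it says the series, first, only, none or still open, it means among the compounds named here.

Compound 1 `COc1cc(-c2cc(/C=C/C(=O)c3ccc(N)cc3)[nH]n2)cc(OC)c1OC` was tested in a functional assay on DU-145 cells (Homo sapiens) for inhibition, read by sulforhodamine B assay, with a stated time of 48 h (a lower number here means that less compound is tolerated, a higher number that more compound is tolerated), and gave 9950 nM. For the measured compounds named here, the only other number at hand comes from compound 2 `COc1ccc(-c2cc(/C=C/C(=O)c3ccc(OC)c(OC)c3)[nH]n2)cc1`, which gave 5640 nM, and the gap between the two lies within the usual scatter, so they cannot be told apart. Compound 3 `COc1ccc(-c2cc(/C=C/C(=O)c3ccc(N)cc3)[nH]n2)cc1OC` differs from compound 1 by hydrogen in place of methoxy on an aromatic carbon. Going by the values given here, no measured pair shows this change, so its effect is unknown; a shift no larger than the scatter, in either direction, is expected, estimated as a 1.1-fold lower number from compound 1 to compound 3 (0.04 log units; within the scatter). Compound 3 is therefore expected to give about 9000 nM, between 4000 nM and 20000 nM.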

Compound 3, concentration lethal to 50% of the cells: 36800 nM
Compound 3: the middle estimate sits 4.1-fold (0.61 log units) below what was measured, and the stated range ends below it.
By their numbers in this assay, from the lowest: compounds 2 and 1 (each within the scatter of the next); then compound 3.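

In this assay hydrogen in place of methoxy gives a 3.7-fold higher number from compound 1 to compound 3 (0.57 log units; beyond the scatter) and so more compound is tolerated once this methoxy is gone. For the compounds shown here, this is the first sign that the position, ortho to a methoxy group on the aromatic ring, matters at all, though it rests on a single pair. Nothing at hand explains the shift. As far as these compounds go, whether a hydroxyl group, a chlorine atom or an ethoxy group at this place would match methoxy remains open. So does whether the same change would act alike on the core of compound 2.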